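The compounds below may be only part of what the source reports. "The series", "measured", "known", "first", "only" and "open" are said of these compounds alone.

Among the measured compounds shown here, compound 1 `Nc1ncnc2c1c(Oc1cc(C(F)(F)F)ccn1)nn2[C@H]1C[C@H](F)C1` gives 2.03 h in an ADME assay on microsomes from liver (Homo sapiens) for metabolic stability, read by LC-MS, using NADPH, with a stated time of 10 min, tested at 10 uM (a higher number here means that the compound lasts longer, a lower number that the compound disappears faster), the highest of the three numbers so far. Compound 2 `Nc1ncnc2c1c(Oc1cc(O)ccn1)nn2[C@H]1C[C@H](F)C1` gives 1.03 h, and compound 3 `Nc1ncnc2c1c(Oc1cc(Cl)ccn1)nn2[C@H]1C[C@H](F)C1` gives 0.833 h. Both measured steps concern the substituent on the aromatic carbon: a 2.0-fold lower number from compound 1 to compound 2 (0.29 log units; within the scatter), and a 2.4-fold lower number from compound 1 to compound 3 (0.39 log units; beyond the scatter). Compound 4 `Nc1ncnc2c1c(Oc1cc(C(F)(F)F)ccn1)nn2[C@@H]1CCCC[C@H]1O` differs from compound 1 at a different place, (2-hydroxycyclohexyl in place of 3-fluorocyclobutyl on an aromatic nitrogen). For the measured compounds named here, no measured step touches the group on the aromatic nitrogen, so this change has no precedent, and no direction beyond the scatter can be read from the data. Compound 4 is therefore estimated at 1.6 h, with a range from 0.7 h to 3.5 h. The expected step is a 1.3-fold lower number from compound 1 to compound 4 (0.10 log units; within the scatter).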

Compound 4, half-life: > 2.41 h
Compound 4: no number, only a limit; the forecaster's own chance of this, stated with the estimate: 5%; middle value at least 1.5-fold (0.17 log units) from the limit.
By their numbers in this assay, from the lowest: compounds 3, 2 and 1 (each within the scatter of the next, the first and the last beyond it). At a limit, above all of these: compound 4.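

In this assay, among the compounds shown here, the only step on the aromatic nitrogen, 2-hydroxycyclohexyl in place of 3-fluorocyclobutyl, is an at least 1.1-fold higher number from compound 1 to compound 4 (0.07 log units; that floor lies within the scatter). This position therefore accepts the six-membered ring with its hydroxy group with no loss in half-life, but the size of any gain cannot be read. Compound 4 is reported only as a limit: the limit of > 2.41 h in this assay, at which 1 of the 4 values shown sits.

Going by these compounds, the hydroxy group and the six-membered ring enter together, so their separate shares stay open. Plain cyclohexyl, or an amine in place of the hydroxy group, would separate them.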